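A few compounds are considered here, and "the series" means these few. Any claim that something is new, unique, unknown or untested is made for them only; others in the source may bear on it.

Measured so far:
- compound 1, `CCC/C(=C\B1OC(C)(C)C(C)(C)O1)C(O)(c1ccccc1)C1CC1`: 55200 nM
- compound 2, `CCCCCCC(C)(O)/C(=C/B1OC(C)(C)C(C)(C)O1)CCC`: 33900 nM

Compound 2 carries the lowest of the two numbers in a functional assay on ARH-77 cells (Homo sapiens) for cytotoxicity, read by MTT assay, with a stated time of 72 h (on this read-out lower numbers stand for stronger inhibition and higher numbers for weaker inhibition), but compound 1 sits only a short way above it, and the gap between them is within the scatter of repeated measurements, so neither compound can be called the stronger of the two.

Compound 3, `CCCCC(C)(O)/C(=C/B1OC(C)(C)C(C)(C)O1)CCC`, differs from compound 2 in one place: hydrogen in place of ethyl on a saturated chain carbon, five bonds along the chain from a double-bonded chain carbon and an oxygen on a saturated carbon. Within the data shown here, no pair of measured compounds shows what this kind of shortening does here, so there is no measured step to lean on. Given how close the two measured numbers already lie, the step from compound 2 to compound 3 is expected to be small, perhaps a slight weakening, but probably not beyond the scatter, as a 1.2-fold higher number from compound 2 to compound 3 (0.09 log units; within the scatter) expresses. Compound 3 is therefore estimated at 42000 nM in this assay, with a plausible range from 15000 nM to 115000 nM.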

Compound 3, half-maximal inhibitory concentration: 54600 nM
Estimate against measurement, compound 3: 1.3-fold (0.11 log units) below; the range from low to high includes it.
By their numbers in this assay, from the lowest: compounds 2, 3 and 1 (each within the scatter of the next).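

In this assay, the exchange of ethyl for hydrogen on a saturated chain carbon, five bonds along the chain from a double-bonded chain carbon and an oxygen on a saturated carbon, gives a 1.6-fold higher number from compound 2 to compound 3 (0.21 log units; within the scatter), the first step measured at this position. The same difference, read as pentyl to propyl, therefore gives no sign that the length of this chain matters in this assay, although a single pair can show this only for these two compounds. No measurement available here bears on the reason for this result.

The compounds shown leave open whether an amine or a carboxylic acid in place of the ethyl would also stay within the scatter of compound 2. They also leave open how a longer chain would read in this assay.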